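Cyanophenyl in Place of Nitrophenyl on a Shared Core

A few compounds are considered here, and "the series" means these few. Any claim that something is new, unique, unknown or untested is made for them only; others in the source may bear on it.

Compound 1, `Cc1cc(Nc2cc(N3CCN(C)CC3)nc(Nc3cccc(Cl)c3)n2)n[nH]1`, gives 425 nM in a functional assay on HeLa cells (Homo sapiens) for antiproliferative activity, read by CCK-8 assay, with a stated time of 72 h; on this read-out higher numbers stand for weaker inhibition and lower numbers for stronger inhibition.
Compound 2, `Cc1cc(Nc2cc(N3CCN(C)CC3)nc(Nc3ccc(Cl)cc3)n2)n[nH]1`, gives 619 nM in this assay.
Compound 3, `Cc1cc(Nc2cc(N3CCN(C)CC3)nc(Nc3cccc([N+](=O)[O-])c3)n2)n[nH]1`, gives 1110 nM in this assay.

Compound 3 stands at the highest of the three numbers. Against compound 2 the gap is a 1.8-fold higher number from compound 2 to compound 3 (0.25 log units; within the scatter), which stays within the scatter; against compound 1 it is a 2.6-fold higher number from compound 1 to compound 3 (0.42 log units; beyond the scatter), a modest step beyond the scatter. The three compounds share one core and differ only in the aryl group on the nitrogen.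

Compound 4, `Cc1cc(Nc2cc(N3CCN(C)CC3)nc(Nc3ccc(C#N)cc3)n2)n[nH]1`, has not yet been measured. Its change from compound 3 is 4-cyanophenyl in place of 3-nitrophenyl on a nitrogen on an aromatic ring. Within the data shown here, two measured steps bear on this. The step of a 2.6-fold higher number from compound 1 to compound 3 (0.42 log units; beyond the scatter) shows that placing nitro where chloro stood raised the number modestly. The step of a 1.8-fold higher number from compound 2 to compound 3 (0.25 log units; within the scatter) shows that going from 4-chlorophenyl to 3-nitrophenyl raised the number, though within the scatter. Returning from 3-nitrophenyl to a 4-substituted phenyl is therefore expected to lower the number somewhat, probably by no more than the scatter. Compound 4 is estimated at 650 nM, with a range of 300 nM to 1400 nM, the expected step being a 1.7-fold lower number from compound 3 to compound 4 (0.23 log units; within the scatter).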

Compound 4, half-maximal inhibitory concentration: 331 nM
Compound 4: middle estimate off by 2.0-fold (0.29 log units), on the high side, and the stated range covers the measured number.
By their numbers in this assay, from the lowest: compounds 4, 1, 2 and 3 (each within the scatter of the next, the first and the last beyond it).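

In this assay, the move from 3-nitrophenyl to 4-cyanophenyl on the nitrogen gives a 3.4-fold lower number from compound 3 to compound 4 (0.53 log units; beyond the scatter) and so crosses the scatter, although this single step changes both the group and where it sits on the phenyl ring. The steps of a 1.9-fold lower number from compound 2 to compound 4 (0.27 log units; within the scatter) and a 1.3-fold lower number from compound 1 to compound 4 (0.11 log units; within the scatter) both stay within the scatter, so the 4-cyanophenyl compound cannot be told apart from either chlorophenyl compound, while compound 3 is separated from compound 1 and compound 4 but not from compound 2. No measurement offered here accounts for these differences.

The four compounds leave open how much of the step from compound 3 to compound 4 belongs to the exchange of nitro for cyano and how much to the different place on the ring. They also leave open how the shared core would respond to a phenyl ring bearing an amine, a carboxylic acid or a methoxy group, or to an aryl group replaced by a longer alkyl chain.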